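A few compounds are considered here, and "the series" means these few. Any claim that something is new, unique, unknown or untested is made for them only; others in the source may bear on it.

In a functional assay on HEK293 cells for agonist activity at D(4) dopamine receptor (Homo sapiens), read by FLIPR (on this read-out lower numbers stand for an effect already at smaller amounts and higher numbers for an effect only at larger amounts of compound), compound 2 `O=C(CN1CCC(c2cccc[n+]2[O-])CC1)NC1CCCCC1` gives 294 nM, the smallest of the three numbers shown, although its gap to compound 3 lies within the scatter. Compound 3 `CCOc1cccc(C(=O)NCN2CCC(c3cccc[n+]3[O-])CC2)c1` gives 324 nM in this assay, and compound 1 `O=C(NCN1CCC(c2cccc[n+]2[O-])CC1)c1cnccc1Cl` gives 1290 nM, a gap from compound 2 that is beyond the scatter. Compound 4 `CSc1cccc(NC(=O)CN2CCC(c3cccc[n+]3[O-])CC2)c1` has not yet been measured in this assay. It differs from compound 2 in one place: 3-(methylsulfanyl)phenyl in place of cyclohexyl on an amide-type nitrogen. Within the data shown here, no measured pair in this set carries that exchange, so its size cannot be read from the data. The expected step of a 1.0-fold higher number from compound 2 to compound 4 (0.01 log units; within the scatter) is small, not beyond the scatter. Compound 4 is therefore estimated at 300 nM, with a range from 90 nM to 1000 nM.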

Compound 4, half-maximal effective concentration: 100 nM
For compound 4 the middle estimate is 3.0-fold (0.48 log units) above the measured one; the measured number falls inside the stated range.
By their numbers in this assay, from the lowest: compound 4; then compounds 2 and 3 (each within the scatter of the next); then compound 1.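

In this assay, 3-(methylsulfanyl)phenyl in place of cyclohexyl on an amide-type nitrogen gives a 2.9-fold lower number from compound 2 to compound 4 (0.47 log units; beyond the scatter), a modest step but beyond the scatter. Among these compounds, this is the first pair in the set that differs in one place, and it shows that this position responds to the exchange and still accepts the larger aromatic group. No supporting data bear on what lies behind the step. From the compounds shown here alone, it remains open whether the aromatic ring or the methylsulfanyl group carries the change; a plain phenyl on the same nitrogen would separate the two.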